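Aryl swap on the amide nitrogen: cytotoxicity limits

The source may hold more compounds than are shown below. What is called first, only, known or untested is meant among the compounds shown, and "the series" means these compounds.

In an ADME assay on MT4 cells (Homo sapiens) for cytotoxicity, read by MTT assay, with a stated time of 5 days (a higher number here means that more compound is tolerated, a lower number that less compound is tolerated), compound 3 (`COc1cc2nc(SCC(=O)Nc3cc([N+](=O)[O-])ccc3F)nc(Nc3c(Cl)cc(/C=C/C#N)cc3Cl)c2cc1OC`) reports only a limit (> 199000 nM), so it has no numerical rank in the series. Compound 1 (`COc1cc2nc(SCC(=O)Nc3cccc(S(N)(=O)=O)c3)nc(Nc3c(Cl)cc(/C=C/C#N)cc3Cl)c2cc1OC`) also reports only a limit (> 194000 nM). Compound 2 (`COc1cc2nc(SCC(=O)Nc3ccc(C(F)(F)F)cc3)nc(Nc3c(Cl)cc(/C=C/C#N)cc3Cl)c2cc1OC`) likewise reports only a limit (> 197000 nM).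

Compound 4 (`COc1cc2nc(SCC(=O)Nc3ccc(C)cc3)nc(Nc3c(Cl)cc(/C=C/C#N)cc3Cl)c2cc1OC`) carries 4-methylphenyl in place of 2-fluoro-5-nitrophenyl on an amide-type nitrogen. Three swaps at this nitrogen bear on the change: (a step that the two limits leave unreadable from compound 1 to compound 3), (a step that the two limits leave unreadable from compound 2 to compound 3) and (a step that the two limits leave unreadable from compound 1 to compound 2). Going by these compounds, none has a readable size, so the direction stays open, and no step beyond the scatter is expected in this assay. The expected step is (a step that the limit leaves unreadable from compound 3 to compound 4). Compound 4 is estimated at (210000 nM), with an expected range from (100000 nM) to (230000 nM).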

Compound 4, half-maximal cytotoxic concentration: 2540 nM
Compound 4: middle estimate off by 83-fold (1.92 log units), on the high side; measured number outside the range, below it.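

At this amide-type nitrogen the aryl group can move the number in this assay, which the earlier limits could not show: 4-methylphenyl brings an at least 78-fold lower number from compound 3 to compound 4 (1.89 log units; beyond the scatter), and set against 3-sulfamoylphenyl it brings an at least 76-fold lower number from compound 1 to compound 4 (1.88 log units; beyond the scatter). Methyl in place of trifluoromethyl on an aromatic carbon, a change at one group only, brings an at least 77-fold lower number from compound 2 to compound 4 (1.88 log units; beyond the scatter). Nothing measured here gives a cause for these steps. Still open, going by these compounds, is whether the methyl itself carries the drop. An ethyl or methoxy group in its place would test how narrowly this holds.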